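The source may hold more compounds than are shown below. What is called first, only, known or untested is meant among the compounds shown, and "the series" means these compounds.

Working notes on the series

The series is read in an assay on isolated protein for inhibition of Aromatase (Homo sapiens), read by fluorescence, tested at 1 uM; a higher number here means more inhibition at the concentration tested (going by the name of the read-out), a lower number less inhibition. Compound 1 `N#Cc1ccc(Oc2cccnc2)cc1Oc1cccnc1` gives 81% in this assay. Compound 2 `N#Cc1ccc(Oc2cccnc2)cc1Oc1cccc(Cl)c1` gives 25% in this assay. Compound 3 `N#Cc1ccc(Oc2cccnc2)c(Oc2cccnc2)c1` gives 82% in this assay; compound 3 and compound 1 have the same atoms joined differently, and the difference between the two cores is not broken down here.

The change from compound 1 to compound 2 is 3-chlorophenyl in place of pyridin-3-yl on an oxygen on an aromatic ring. It gave a number 56 percentage points lower from compound 1 to compound 2 (beyond the scatter).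

Compound 4 `N#Cc1ccc(Oc2cccnc2)c(Oc2cccc(Cl)c2)c1` is not yet measured in this assay. It differs from compound 3 by 3-chlorophenyl in place of pyridin-3-yl on an oxygen on an aromatic ring, the same change as in the measured pair, at the same kind of place.

Compound 4 is expected to give 26% in this assay, a step of a number 56 percentage points lower from compound 3 to compound 4 (beyond the scatter), because the same change gave a number 56 percentage points lower from compound 1 to compound 2 (beyond the scatter) and compound 3 starts from 82%.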

Compound 4, a percentage reported as inhibition, at one concentration (the size of the read-out at that concentration, not a potency): 89%
Compound 4: the middle estimate sits 63 percentage points below what was measured; measured number outside the range, above it.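

In this assay, 3-chlorophenyl in place of pyridin-3-yl on an oxygen on an aromatic ring does not carry over from the core of compound 1 to the core of compound 3, where the result is a number 7 percentage points higher from compound 3 to compound 4 (within the scatter). The two steps differ: the same change on two cores in this assay, a number 56 percentage points lower (beyond the scatter) from compound 1 to compound 2 and a number 7 percentage points higher (within the scatter) from compound 3 to compound 4, 63 percentage points apart, beyond the scatter of two such steps. The outcome of this change therefore depends on the core in these two pairs, but the data do not show which feature of the cores sets the difference, and two pairs give no rule for any further core.

Still open, going by these compounds, is whether the same split between the two cores appears with other groups on that oxygen, such as a carboxylic acid or a longer chain in place of pyridin-3-yl. Also open, on these data alone, is how either core reads with an amine in place of the nitrile.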